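Bromo to methylamino on the fused core of compound 2

The source may report more compounds than this note shows. Statements on the series, on what has been measured and on what is new or still open speak of the compounds shown alone.

Of the compounds shown here, two have been measured in a functional assay (Oryctolagus cuniculus) for inhibition; a higher number here means a weaker inhibitor, a lower number a stronger inhibitor. Compound 1, `CC(=O)OCCOCn1cc(/C=C/Br)c(=O)[nH]c1=O`, reaches only a limit: in this assay compound 1 gives > 400 ug/mL, which is a limit rather than a number. Within the data shown here, compound 2, `Nc1nc2c(nc(Br)n2COCCO)c(=O)[nH]1`, is the one compound with a measured number; in this assay compound 2 gives 225 ug/mL. Among the measured compounds shown here, the set of values also includes (the limit of > 400 ug/mL in this assay, at which 1 of the 2 values shown sits), so compound 2 stands as the single number in the set, with nothing to set beside it except that limit. The third compound, compound 3, `CNc1nc2c(=O)[nH]c(N)nc2n1COCCO`, has not been measured. It differs from compound 2 in one place: methylamino in place of bromo on an aromatic carbon. For the measured compounds named here, no measured pair in this set shows a change of this kind, so the size of such a step cannot be read from the data. The step of a 1.1-fold higher number from compound 2 to compound 3 (0.05 log units; within the scatter) is expected to stay within the usual scatter, with no clear direction. Compound 3 is therefore estimated at 250 ug/mL, with a range from 80 ug/mL to 600 ug/mL.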

Compound 3, concentration for 50% inhibition: > 400 ug/mL
Compound 3 ended at the assay's limit; the forecaster's own chance of this, stated with the estimate: 40%; middle value at least 1.6-fold (0.20 log units) away from the limit.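

Methylamino in place of bromo on the aromatic carbon between two ring nitrogen atoms gives an at least 1.7-fold higher number from compound 2 to compound 3 (0.24 log units; that floor lies within the scatter) in this assay, and this is the first step in the set that touches this position. Compound 3 yields only a limit and not a number, so the change gives no stronger inhibitor here, although the floor of the step is not enough on its own to establish a real loss. Because compound 3 stops at the limit, compound 2 remains the only compound with a number and the true size of the step cannot be read: the limit of > 400 ug/mL in this assay, at which 2 of the 3 values shown sit.

What the compounds shown leave open is how far inhibition at this carbon depends on bromo, as a plain amine, a chlorine atom or a longer chain such as ethylamino could each return either a number or another limit. They also do not separate the effect of losing bromo from that of bringing in methylamino, and compound 1, which differs from compound 2 in more than one place, offers no comparison that could settle it.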